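This account rests on a few compounds, and the source may have more. Where it says the series, first, only, none or still open, it means among the compounds named here.

Working notes on the thiazolo-fused series.

Compound 1 `CC1(C)CC(=O)c2s/c(=N/c3ccc(Cl)cc3)oc2C1` is the reference point. In a functional assay on ACHN cells (Homo sapiens) for antiproliferative activity, read by sulforhodamine B assay (a higher number here means a weaker inhibitor of growth, a lower number a stronger inhibitor of growth), compound 1 gives 9810 nM. Compound 2 `CC1CC(=O)c2s/c(=N/c3ccc(Cl)cc3)oc2C1` keeps the same core and the same chlorophenyl imine; in this assay compound 2 gives 12400 nM. The change from compound 1 to compound 2 is hydrogen in place of methyl on a saturated ring carbon and the measured step is a 1.3-fold higher number from compound 1 to compound 2 (0.10 log units; within the scatter), so the two values are not told apart by this assay.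

Compound 3 `CC1(C)CC(=O)c2s/c(=N/c3c(Cl)cc(Cl)cc3Cl)oc2C1` carries the trichlorophenyl imine on the gem-dimethyl core. For compound 3 this assay reports only a limit, > 30000 nM, and no number. The difference between the core of compound 1 and the core of compound 3 is not broken down here.

Compound 4 `CC1CC(=O)c2s/c(=N/c3c(Cl)cc(Cl)cc3Cl)oc2C1` has not yet been measured. It differs from compound 3 by hydrogen in place of methyl on a saturated ring carbon, which is the same change that separates compound 1 from compound 2, and the surroundings of the place are the same in both pairs.

Expectation for compound 4: the step from compound 3 to compound 4 in this assay is estimated as a step that the limit leaves unreadable from compound 3 to compound 4, resting on the small measured step of a 1.3-fold higher number from compound 1 to compound 2 (0.10 log units; within the scatter) and on the fact that compound 3 already sits at the limit of > 30000 nM in this assay, at which 1 of the 3 values shown sits. Compound 4 is therefore expected to come out near 40000 nM, most likely again as a limit rather than a number, with a range from 15000 nM to 100000 nM.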

Compound 4, concentration for 50% growth inhibition: > 30000 nM
Compound 4: no number, only a limit; the forecaster's own chance of this, stated with the estimate: 70%; the middle value lies beyond the limit too.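

In this assay compound 4 gives only a limit, > 30000 nM, and no number. Compound 3 also gives only a limit, so no step from compound 3 to compound 4 can be read, and both rest on the same limit: the limit of > 30000 nM in this assay, at which 2 of the 4 values shown sit.

The compounds shown leave open whether hydrogen in place of methyl on a saturated ring carbon changes growth inhibition at all with the trichlorophenyl imine in place.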